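Methyl on the Shared Aromatic Ring: Two Parallel Steps

The source may report more compounds than this note shows. Statements on the series, on what has been measured and on what is new or still open speak of the compounds shown alone.

Compound 1 `O=C1CC(c2c(-c3ccc[nH]3)[nH]c3ccccc23)C(=O)N1` gives 8000 nM in a functional assay on A549 cells (Homo sapiens) for cytotoxicity, read by MTT assay, with a stated time of 72 h; on this read-out higher numbers stand for weaker inhibition and lower numbers for stronger inhibition.
Compound 2 `Cc1ccc2[nH]c(-n3cccn3)c(C3=C(Br)C(=O)NC3=O)c2c1` gives 29000 nM in this assay.
Compound 3 `O=C1NC(=O)C(c2c(-n3cccn3)[nH]c3ccccc23)=C1Br` gives 25000 nM in this assay.

Among these three, compound 1 has the lowest number in this assay; compound 3 is its nearest neighbour and compound 2 lies furthest from it. Compound 3 and compound 2 differ in a single place: methyl in place of hydrogen on an aromatic carbon. That change produced a 1.2-fold higher number from compound 3 to compound 2 (0.06 log units; within the scatter), a step that does not rise above the scatter of repeated measurements. The difference between the core of compound 1 and the core of compound 3 is not broken down here.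

Compound 4 `Cc1ccc2[nH]c(-c3ccc[nH]3)c(C3CC(=O)NC3=O)c2c1` has not yet been measured. It relates to compound 1 in the same way that compound 2 relates to compound 3: methyl in place of hydrogen on an aromatic carbon. The two descriptions of where the methyl enters match word for word, so this is the same change. Because the earlier instance gave a 1.2-fold higher number from compound 3 to compound 2 (0.06 log units; within the scatter), only a small step is expected here, namely a 1.2-fold higher number from compound 1 to compound 4 (0.07 log units; within the scatter). In this assay compound 4 is therefore estimated at 9500 nM, with a likely range from 4500 nM to 20000 nM.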

Compound 4, half-maximal inhibitory concentration: 20000 nM
For compound 4 the middle estimate is 2.1-fold (0.32 log units) below the measured one, and the stated range covers the measured number.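

In this assay, placing a methyl on the aromatic carbon of the core of compound 1 gives a 2.5-fold higher number from compound 1 to compound 4 (0.40 log units; beyond the scatter) and so moves the number towards weaker inhibition, a modest but readable loss on this core. Set beside the earlier step on the other core, this step cannot be told apart from it: the same change on two cores in this assay, a 1.2-fold higher number (0.06 log units; within the scatter) from compound 3 to compound 2 and a 2.5-fold higher number (0.40 log units; beyond the scatter) from compound 1 to compound 4, 2.2-fold (0.33 log units) apart, within the scatter of two such steps. Within the data shown here, this shows that the change carried across the two cores without a clear difference in its effect, but with only one pair on each core and a single assay, it does not show that the step is the same size on both, nor that it would hold on a further core.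

The compounds shown leave open how an amine, a carboxylic acid or a longer chain would behave on the same aromatic carbon in place of the methyl. On these data alone, the core of compound 1 and the core of compound 3 differ in more than one place, and which of those differences matters also stays open.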